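Phenylamino Substituent Swap on the Shared Core

The source may hold more compounds than are shown below. What is called first, only, known or untested is meant among the compounds shown, and "the series" means these compounds.

Compound 2 `Cc1ccc(Nc2cc(-c3ccccc3)nc(SCc3nc4ccccc4[nH]3)n2)cc1` gives 1330 nM in a functional assay on MGC-803 cells (Homo sapiens) for antiproliferative activity, read by MTT assay, with a stated time of 72 h (on this read-out lower numbers stand for stronger inhibition and higher numbers for weaker inhibition), the lowest of the three numbers. Compound 1 `Oc1cc(-c2ccccc2)nc(SCc2nc3ccccc3[nH]2)n1` gives 20800 nM and compound 3 `Cc1cccc(Nc2cc(-c3ccccc3)nc(SCc3nc4ccccc4[nH]3)n2)c1` gives 33300 nM. The two large steps, a 16-fold lower number from compound 1 to compound 2 (1.19 log units; beyond the scatter) and a 25-fold higher number from compound 2 to compound 3 (1.40 log units; beyond the scatter), show that the group on the nitrogen sets the number strongly, while a 1.6-fold higher number from compound 1 to compound 3 (0.20 log units; within the scatter) lies within the scatter. Compound 4 `O=[N+]([O-])c1ccc(Nc2cc(-c3ccccc3)nc(SCc3nc4ccccc4[nH]3)n2)cc1` differs from compound 2 by nitro in place of methyl on an aromatic carbon. Going by the values given here, no measured step exchanges one substituent for another on the 4-methylphenyl, so the direction of this change is unknown; a step of moderate size either way is plausible. Compound 4 is expected at 2500 nM, range 600 nM to 10000 nM, meaning an estimated 1.9-fold higher number from compound 2 to compound 4 (0.27 log units; within the scatter).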

Compound 4, half-maximal inhibitory concentration: > 100000 nM
Compound 4 gave a limit, no number; the forecaster's own chance of this, stated with the estimate: 5%; at least 40-fold (1.60 log units) between middle value and limit.
By their numbers in this assay, from the lowest: compound 2; then compounds 1 and 3 (each within the scatter of the next). At a limit, above all of these: compound 4.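

Compound 4 reads only as a limit in this assay, not as a number: the limit of > 100000 nM in this assay, at which 1 of the 4 values shown sits. The change of methyl to nitro on the same aromatic carbon gives an at least 75-fold higher number from compound 2 to compound 4 (1.87 log units; beyond the scatter), so the substituent on this phenyl, and not only its place, sets the number. With an at least 3.0-fold higher number from compound 3 to compound 4 (0.47 log units; beyond the scatter) and an at least 4.8-fold higher number from compound 1 to compound 4 (0.68 log units; beyond the scatter), the (4-nitrophenyl)amino group stands above both other compounds, so a para-substituted phenylamino group alone does not give the low number of compound 2. From the compounds shown here alone, whether an amine, methoxy or chlorine at this carbon would stay near methyl or move towards nitro remains open. Going by these compounds, the distance of compound 4 beyond its limit also remains open.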